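Exchanging the Ring on the Sulfonamide Sulfur

The compounds below may be only part of what the source reports. "The series", "measured", "known", "first", "only" and "open" are said of these compounds alone.

Compound 1, `Cc1noc(C)c1S(=O)(=O)N1CCC(N2CCC(C)CC2)CC1`, gives > 10000 nM in an ADME assay on HCT-116 cells (Homo sapiens) for cytotoxicity, read by CellTiter-Glo, with a stated time of 72 h (a lower number here means a stronger inhibitor, a higher number a weaker inhibitor), which is a limit of the assay rather than a number.
Compound 2, `Cc1ccc(-c2ccccc2S(=O)(=O)N2CCC(N3CCC(C)CC3)CC2)cc1`, gives > 5000 nM in this assay, also a limit rather than a number.

Compound 1 therefore stands at the limit of > 10000 nM in this assay, at which 1 of the 2 values shown sits, so nothing more precise than weak cytotoxicity is known for it. Compound 3, `Cc1ccc(S(=O)(=O)N2CCC(N3CCC(C)CC3)CC2)cc1C`, carries 3,4-dimethylphenyl in place of 3,5-dimethyl-1,2-oxazol-4-yl on a sulfonyl sulfur. Within the data shown here, no step between measured compounds exists here, and no change beyond the usual scatter is expected; the step is estimated as a step that the limit leaves unreadable from compound 1 to compound 3. Compound 3 is expected to give about 12000 nM, in the range 4000 nM to 40000 nM, most probably again reported only as a limit.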

Compound 3, half-maximal inhibitory concentration: > 5000 nM
Compound 3: only a limit was reported; the forecaster's own chance of this, stated with the estimate: 80%; the middle value is on the limit's open side.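

Compound 1 and compound 3 are both reported only as limits in this assay, and the step between them cannot be read. The compounds shown leave open whether exchanging the ring on the sulfonyl sulfur changes cytotoxicity at all.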